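Mirror-Image Partner of Compound 3: An Expectation

The source may hold more compounds than are shown below. What is called first, only, known or untested is meant among the compounds shown, and "the series" means these compounds.

Three compounds sharing one core have numbers in an assay on frontal cortex for displacement of a labelled ligand from corticotropin-releasing factor receptor 1 (Rattus norvegicus); a lower number here means a stronger inhibitor, a higher number a weaker inhibitor. Compound 1, `CC[C@H](C1CC1)n1cc(Cl)nc(Nc2cc(C)c(OC)nc2C)c1=O`, gives 0.28 nM. Among the compounds with values here, compound 2, `CC[C@H](C1CC1)n1cc(C#N)nc(Nc2cc(C)c(OC)nc2C)c1=O`, gives 1.7 nM, and the change a 6.1-fold higher number from compound 1 to compound 2 (0.78 log units; beyond the scatter) is the only step between measured compounds that differ in one place. Compound 3, `COC[C@H](C1CC1)n1cc(Cl)nc(Nc2cc(C#N)c(OC(F)F)nc2C)c1=O`, gives 0.86 nM, which is the second highest of the three numbers: its gap to compound 2 lies within the scatter, while its gap to compound 1 lies beyond it.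

Compound 4, `COC[C@@H](C1CC1)n1cc(Cl)nc(Nc2cc(C#N)c(OC(F)F)nc2C)c1=O`, differs from compound 3 as follows: the two compounds have the same atoms and bonds and differ only in configuration as drawn: 1 of 1 stereo elements differ; a stereocentre at a saturated chain carbon is drawn S in compound 3 and R in compound 4. Within the data shown here, no measured step bears on such an inversion, since no other pair in this set differs only in configuration; the step from compound 1 to compound 2 concerns a substituent, not a stereocentre, and says nothing about it. The direction and size of the step in this assay are therefore open, and any estimate must carry a wide range. Compound 4 is expected to give 4 nM, between 0.6 nM and 40 nM, which would mean an expected step of a 4.7-fold higher number from compound 3 to compound 4 (0.67 log units; beyond the scatter).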

Compound 4, half-maximal inhibitory concentration: 1.4 nM
Estimate against measurement, compound 4: 2.9-fold (0.46 log units) above, and the stated range covers the measured number.
By their numbers in this assay, from the lowest: compound 1; then compounds 3, 4 and 2 (each within the scatter of the next).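

Within the data shown here, the first pair to differ only at a stereocentre shows that, in this assay, inverting the saturated chain carbon from S to R gives a 1.6-fold higher number from compound 3 to compound 4 (0.21 log units; within the scatter). This assay therefore does not separate these two mirror-image forms, so in this pair the drawn configuration at this position has no effect that can be read beyond the scatter. Any gap between the two numbers can be assigned only to that stereocentre, because nothing else in the structures separates them: the fact that compounds 3 and 4 differ only in the configuration as drawn.

The compounds shown leave open whether the same inversion would be equally small with the other substituents of compound 1 or compound 2. They also leave open whether it would stay so if a hydroxyl group or a longer chain stood at this stereocentre.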